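The source may report more compounds than this note shows. Statements on the series, on what has been measured and on what is new or still open speak of the compounds shown alone.

Among the compounds with values here, in a functional assay on SF-539 cells (Homo sapiens) for inhibition, read by sulforhodamine B assay, with a stated time of 48 h (on this read-out lower numbers stand for stronger inhibition of growth and higher numbers for weaker inhibition of growth), compound 2 (`CCCCCCCCCCCC[C@@H](O)[C@H]1CC[C@H]([C@H](O)CCCCCCCCCCC(=O)Nc2ccnn2C)O1`) gives 100000 nM, the higher of the two numbers measured so far, while compound 1 (`CCCCCCCCCCCC[C@@H](O)[C@H]1CC[C@H]([C@H](O)CCCCCCCCCCNC(=O)c2ccnn2C)O1`) gives 3720 nM. Compound 3 (`CCCCCCCCCCCC[C@@H](O)[C@H]1CC[C@H]([C@H](O)CCCCCCCCCCOC(=O)c2ccnn2C)O1`) differs from compound 2 as follows: ((1-methyl-1H-pyrazol-5-yl)carbonyl)oxy in place of (1-methyl-1H-pyrazol-5-yl)carbamoyl on a saturated chain carbon, ten or more bonds along the chain from an oxygen on a saturated carbon and a saturated ring carbon. Within the data shown here, one measured step bears on this, the large 27-fold higher number from compound 1 to compound 2 (1.43 log units; beyond the scatter), which is beyond the scatter. The entering ((1-methyl-1H-pyrazol-5-yl)carbonyl)oxy reads like the ((1-methyl-1H-pyrazol-5-yl)carbonyl)amino of compound 1 at 3720 nM, with oxy for amino, so a large move toward lower numbers is expected. The expected change is a 17-fold lower number from compound 2 to compound 3 (1.22 log units; beyond the scatter). For compound 3 the estimate is 6000 nM, with an expected range of 1500 nM to 30000 nM.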

Compound 3, concentration for 50% growth inhibition: 100000 nM
The estimate for compound 3 lay 17-fold (1.22 log units) below the measured number; the whole stated range lies below it.
By their numbers in this assay, from the lowest: compound 1; then compounds 2 and 3 (each within the scatter of the next).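

In this assay, swapping amino for oxy in the ((1-methyl-1H-pyrazol-5-yl)carbonyl)amino group of compound 1 does not keep its growth inhibition (a 27-fold higher number from compound 1 to compound 3 (1.43 log units; beyond the scatter)). The ((1-methyl-1H-pyrazol-5-yl)carbonyl)oxy group instead reads the same as the (1-methyl-1H-pyrazol-5-yl)carbamoyl group (no change at the digits printed from compound 2 to compound 3 (within the scatter)), so among these three compounds only compound 1 stands apart at this chain position. Nothing measured here accounts for the difference. Still open, going by these compounds, is whether an amine at this chain position, or a longer chain carrying the ((1-methyl-1H-pyrazol-5-yl)carbonyl)amino group, would keep the number of compound 1.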